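The compounds below may be only part of what the source reports. "The series", "measured", "known", "first", "only" and "open" are said of these compounds alone.

Measured compounds:
compound 1, `CCN(CC)CCn1c(N)c(-c2nc3ccccc3[nH]2)c2nc(C#N)c(C#N)nc21` — 8950 nM
compound 2, `N#Cc1nc2c(-c3nc4ccccc4[nH]3)c(N)n(CCN3CCCC3)c2nc1C#N` — > 50000 nM
compound 3, `CCCCn1c(N)c(-c2nc3ccccc3[nH]2)c2nc(C#N)c(C#N)nc21` — > 50000 nM

Among the measured compounds shown here, in a functional assay on Raji cells (Homo sapiens) for antiproliferative activity, read by MTT assay, with a stated time of 48 h (on this read-out lower numbers stand for stronger inhibition and higher numbers for weaker inhibition), compound 1 gives 8950 nM, the only number among the three. Compound 2 reaches only a limit of this assay, > 50000 nM. Compound 3 likewise stops at a limit, > 50000 nM. Both limits are the same one, (the limit of > 50000 nM in this assay, at which 2 of the 3 values shown sit). The steps read accordingly: an at least 5.5-fold higher number from compound 1 to compound 2 (0.74 log units; beyond the scatter) and an at least 5.5-fold higher number from compound 1 to compound 3 (0.74 log units; beyond the scatter), while a step that the two limits leave unreadable from compound 2 to compound 3.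

Compound 4, `N#Cc1nc2c(-c3nc4ccccc4[nH]3)c(N)n(CCCN3CCCCC3)c2nc1C#N`, is not yet measured in this assay. It differs from compound 1 in one place: (piperidin-1-yl)methyl in place of diethylamino on a saturated chain carbon, two bonds along the chain from an aromatic nitrogen. For the measured compounds named here, the closest measured step is the one to compound 2, where a cyclic amine also took the place of diethylamino, and the step to compound 3 points the same way. Compound 4 is therefore expected to fall well away from compound 1, with a substantial chance of stopping at the same limit; the expected step is a 5.0-fold higher number from compound 1 to compound 4 (0.70 log units; beyond the scatter). The estimate for compound 4 is 45000 nM, between 12000 nM and 150000 nM.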

Compound 4, half-maximal inhibitory concentration: 3380 nM
For compound 4 the middle estimate is 13-fold (1.12 log units) above the measured one, outside the stated range (below it).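

In this assay, a cyclic amine at the end of the chain need not cost activity: 3-(piperidin-1-yl)propyl in place of 2-(diethylamino)ethyl gives a 2.6-fold lower number from compound 1 to compound 4 (0.42 log units; beyond the scatter). The same chain also separates clearly from the butyl and 2-(pyrrolidin-1-yl)ethyl chains, with an at least 14-fold lower number from compound 3 to compound 4 (1.17 log units; beyond the scatter) and an at least 14-fold lower number from compound 2 to compound 4 (1.17 log units; beyond the scatter). These last two steps start from a limit and not from a number: the limit of > 50000 nM in this assay, at which 2 of the 4 values shown sit.

The compounds shown leave open whether the ring or the longer chain carries the change, since ring size and chain length differ together between compound 2 and compound 4, and 2-(piperidin-1-yl)ethyl and 3-(pyrrolidin-1-yl)propyl would separate the two. From the compounds shown here alone, how 3-(diethylamino)propyl or a morpholine ring at the end of the propyl chain would read also remains open.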